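The source may hold more compounds than are shown below. What is called first, only, known or untested is meant among the compounds shown, and "the series" means these compounds.

Measured compounds: compound 1 `O=C(Cc1cccnc1)c1cc2c(O)cccc2[nH]1` gave 83000 nM in an assay on isolated protein for inhibition of Indoleamine 2,3-dioxygenase 1 (Homo sapiens), read by spectrophotometry; on this read-out lower numbers stand for stronger inhibition and higher numbers for weaker inhibition; compound 3 `COc1ccc2[nH]c(C(=O)Cc3cccnc3)cc2c1` gave 49000 nM in this assay; compound 2 `O=C(Cc1ccncc1)c1cc2ccccc2[nH]1` was reported in this assay as "not active" (no number reported).

Compound 2 therefore stands without a single number in this assay; its report states only that no inhibition was found, whereas compound 1 and compound 3, which carry a substituent on the shared core, each gave a weak but countable value that the usual scatter does not separate. The unmeasured compound 4 `O=C(Cc1cnccn1)c1cc2ccccc2[nH]1` keeps the core of compound 2 and differs from it in one place: pyrazin-2-yl in place of pyridin-4-yl on a saturated chain carbon bound to a carbonyl carbon. Going by the values given here, with no measured pair bracketing this change, the size of the step in this assay cannot be read from the data; the expectation rests on compound 2 being reported as "not active" (no number reported) and on compound 1 and compound 3 both sitting at very weak values. The account expects compound 4 to remain weak, with a fair chance that only a limit is reported, and estimates its value in this assay at 100000 nM, within a range from 30000 nM to 300000 nM.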

Compound 4, half-maximal inhibitory concentration: 26200 nM
For compound 4 the middle estimate is 3.8-fold (0.58 log units) above the measured one; the whole stated range lies above it.
By their numbers in this assay, from the lowest: compounds 4, 3 and 1 (each within the scatter of the next, the first and the last beyond it).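

Going by these compounds alone, compound 2 carries no number in this assay, and no step from it to compound 4, which gives 26200 nM, can be read. The compounds shown leave open how far pyrazin-2-yl in place of pyridin-4-yl shifts inhibition on this core. No measurement shown offers an explanation for the value of compound 4.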